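Cyclopropyloxy in place of cyclopropylmethyl on the shared core

The compounds below may be only part of what the source reports. "The series", "measured", "known", "first", "only" and "open" are said of these compounds alone.

Compound 2 `c1ccc(OCC2=NCCN2)c(CC2CC2)c1` gives 501 nM in an assay on isolated protein for binding affinity to Alpha-2B adrenergic receptor (Homo sapiens) (on this read-out higher numbers stand for weaker inhibition and lower numbers for stronger inhibition), and compound 1 `C=CCc1ccccc1OCC1=NCCN1` gives 708 nM in this assay; the step of a 1.4-fold lower number from compound 1 to compound 2 (0.15 log units; within the scatter) leaves the two within the scatter, so no order between them can be read. Compound 3 `c1ccc(OC2CC2)c(OCC2=NCCN2)c1` carries cyclopropyloxy in place of cyclopropylmethyl on an aromatic carbon. Among the compounds with values here, the single measured step touched the same group and stayed within the scatter, and no measured pair speaks to exchanging cyclopropylmethyl for cyclopropyloxy, so the expected step of a 1.2-fold higher number from compound 2 to compound 3 (0.08 log units; within the scatter) is none beyond the scatter, with a wide margin either way. For compound 3 the estimate in this assay is 600 nM, within 200 nM to 1800 nM.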

Compound 3, inhibition constant: 794 nM
Estimate against measurement, compound 3: 1.3-fold (0.12 log units) below; measured number inside the range.
By their numbers in this assay, from the lowest: compounds 2, 1 and 3 (each within the scatter of the next).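

Against cyclopropylmethyl, cyclopropyloxy on this aromatic carbon gives a 1.6-fold higher number from compound 2 to compound 3 (0.20 log units; within the scatter) and against allyl it gives a 1.1-fold higher number from compound 1 to compound 3 (0.05 log units; within the scatter), and both steps in this assay stay within the scatter. Adding an oxygen and its hydrogen-bond acceptor to the group here therefore produces no step that can be read, and all three groups remain within the scatter of one another. No evidence at hand bears on this result.

On these data alone, what an amine, a carboxylic acid or a longer chain on this aromatic carbon would do in this assay stays open, as does whether any group here moves the number beyond the scatter.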